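This account rests on a few compounds, and the source may have more. Where it says the series, first, only, none or still open, it means among the compounds named here.

Among the three measured compounds, compound 3 `CCOC(=O)C1=Cc2ccccc2OC1(OCc1cn(-c2ccc(F)c([N+](=O)[O-])c2)nn1)C(F)(F)F` alone gives a number in a functional assay on HeLa cells (Homo sapiens) for inhibition, read by MTT assay, with a stated time of 24 h; on this read-out higher numbers stand for weaker inhibition and lower numbers for stronger inhibition: compound 3 gives 15600 nM. Compound 1 `CCOC(=O)C1=Cc2ccccc2OC1(OCc1cn(-c2cccc(OC)c2)nn1)C(F)(F)F` reaches only a limit in this assay, giving > 150000 nM. Compound 2 `CCCCCCCCn1cc(COC2(C(F)(F)F)Oc3ccccc3C=C2C(=O)OCC)nn1` likewise gives only a limit, > 150000 nM. The readable steps are an at least 9.6-fold lower number from compound 1 to compound 3 (0.98 log units; beyond the scatter) and an at least 9.6-fold lower number from compound 2 to compound 3 (0.98 log units; beyond the scatter), while a step that the two limits leave unreadable from compound 1 to compound 2. Compound 4 `CCOC(=O)C1=Cc2ccccc2OC1(OCc1cn(-c2ccc([N+](=O)[O-])cc2)nn1)C(F)(F)F` carries 4-nitrophenyl in place of 4-fluoro-3-nitrophenyl on an aromatic nitrogen. Both measured steps exchange a non-nitro group for 4-fluoro-3-nitrophenyl, so neither is a move between two nitrophenyl groups; they bear on this change only loosely, and the expected change in this assay is a step of a 1.6-fold higher number from compound 3 to compound 4 (0.20 log units; within the scatter), within or near the scatter. Compound 4 is therefore expected to give about 25000 nM, in the range 8000 nM to 80000 nM.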

Compound 4, half-maximal inhibitory concentration: > 150000 nM
Compound 4 ended at the assay's limit (the forecaster's own chance of this, stated with the estimate: 15%); middle value at least 6.0-fold (0.77 log units) away from the limit.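

The exchange on the aromatic nitrogen gives an at least 9.6-fold higher number from compound 3 to compound 4 (0.98 log units; beyond the scatter) in this assay. The earlier steps shown here set 4-fluoro-3-nitrophenyl only against groups without a nitro group; this one shows that a nitrophenyl group on this nitrogen does not by itself give a readable number. The steps to compound 4 from compound 1 and compound 2 cannot be read because both ends of each are limits: the limit of > 150000 nM in this assay, at which 3 of the 4 values shown sit.

Since 4-nitrophenyl differs from 4-fluoro-3-nitrophenyl both in the fluorine and in where the nitro group stands, the compounds shown do not tell these two apart. A 3-nitrophenyl or a 4-fluorophenyl group on the same nitrogen would separate them.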